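The source may report more compounds than this note shows. Statements on the series, on what has been measured and on what is new or still open speak of the compounds shown alone.

Measured compounds:
- compound 1, `O=C(/C(=C/c1ccc(O)c([N+](=O)[O-])c1)SCc1ccc(Br)cc1)c1ccc([N+](=O)[O-])c(Cl)c1`: 1000 nM
- compound 2, `O=C(/C(=C\c1ccc(O)cc1)S(=O)(=O)Cc1ccc(F)cc1)c1ccc(Br)cc1`: 10000 nM

In a functional assay on DU-145 cells (Homo sapiens) for inhibition, read by trypan blue exclusion, with a stated time of 96 h (a higher number here means a weaker inhibitor of growth, a lower number a stronger inhibitor of growth), compound 1 gives 1000 nM and compound 2 gives 10000 nM. Compound 2 thus stands as the higher of the two numbers, and its gap to compound 1 lies beyond the scatter; the two differ in several places at once, so the numbers alone tell nothing about which change carries the gap.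

The next compound is compound 3, `COc1ccccc1/C=C(\C(=O)c1ccc(Br)cc1)S(=O)(=O)Cc1ccc(F)cc1`, which differs from compound 2 in one place only:

2-methoxyphenyl in place of 4-hydroxyphenyl on a double-bonded chain carbon bound to a double-bonded chain carbon

Within the data shown here, no step between measured compounds touches this part of the structure, so there is no measured guide for the size or direction of the move. Among the measured compounds shown here, with compound 2 already at the high end of the two numbers and no comparable step on record, the expectation is a change no larger than the scatter, in either direction. The step from compound 2 to compound 3 is estimated as no change at the digits printed from compound 2 to compound 3 (within the scatter) in this assay. Compound 3 is accordingly expected to give about 10000 nM in this assay, within a range of 3000 nM to 30000 nM.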

Compound 3, concentration for 50% growth inhibition: 25000 nM
Estimate against measurement, compound 3: 2.5-fold (0.40 log units) below, within the range that was stated.
By their numbers in this assay, from the lowest: compound 1; then compound 2; then compound 3.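

In this assay, the replacement of 4-hydroxyphenyl by 2-methoxyphenyl on a double-bonded chain carbon bound to a double-bonded chain carbon gives a 2.5-fold higher number from compound 2 to compound 3 (0.40 log units; beyond the scatter), so this position responds to a change of aryl group, here towards weaker growth inhibition, though only modestly. The change removes the hydrogen-bond donor of the leaving group and adds one heavy atom, while also altering where the oxygen group sits on the aromatic ring, and this single step cannot separate these differences from one another. Nothing measured here bears on why the number moves in this direction.

Still open, from the compounds shown here alone, is whether 4-methoxyphenyl or 2-hydroxyphenyl at this position would stand closer to compound 2 or to compound 3, since either group would help separate the identity of the oxygen group from its place on the ring. Also open, going by these compounds, are the result of a 4-aminophenyl group here, which would keep a nitrogen-bound hydrogen in the place of the hydroxyl, and whether the same replacement would give a step of similar size and direction in the background of compound 1.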